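Dimethylamino in Place of Amino on the Thiocarbonyl Carbon

The source may report more compounds than this note shows. Statements on the series, on what has been measured and on what is new or still open speak of the compounds shown alone.

Measured so far in a functional assay on B16 cells (Mus musculus), read by spectrophotometry, with a stated time of 3 days; a higher number here means a weaker inhibitor, a lower number a stronger inhibitor:
compound 1, `CCNC(=S)N/N=C/c1cccc2ccccc12`, 1100 nM
compound 2, `CN(C)C(=S)N/N=C/c1cccc2ccccc12`, 280 nM
compound 3, `CN(/N=C/c1cccc2ccccc12)C(N)=S`, 1600 nM

Compound 3 stands highest of these three numbers in this assay; its gap to compound 1 is within the scatter, while a 5.7-fold higher number from compound 2 to compound 3 (0.76 log units; beyond the scatter) is beyond it. Compound 4, `CN(C)C(=S)N(C)/N=C/c1cccc2ccccc12`, differs from compound 3 by dimethylamino in place of amino on a thiocarbonyl carbon. Going by the values given here, the one measured step of the same kind, a dimethylamino replacing an alkylamino on the thiocarbonyl carbon, is a 3.9-fold lower number from compound 1 to compound 2 (0.59 log units; beyond the scatter). The other steps, a 1.5-fold higher number from compound 1 to compound 3 (0.16 log units; within the scatter) and a 5.7-fold higher number from compound 2 to compound 3 (0.76 log units; beyond the scatter), concern a different place and bear only indirectly. A lower number of similar size is therefore expected for compound 4, about a 3.6-fold lower number from compound 3 to compound 4 (0.55 log units; beyond the scatter). Compound 4 is estimated at 450 nM, within 150 nM to 1400 nM.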

Compound 4, half-maximal inhibitory concentration: 8600 nM
Estimate against measurement, compound 4: 19-fold (1.28 log units) below; the whole stated range lies below it.
By their numbers in this assay, from the lowest: compound 2; then compounds 1 and 3 (each within the scatter of the next); then compound 4.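

On the thiocarbonyl carbon, dimethylamino in place of amino brings a 5.4-fold higher number from compound 3 to compound 4 (0.73 log units; beyond the scatter) in this assay, which runs opposite to the earlier lower number on moving from ethylamino to dimethylamino. Going by these compounds alone, the effect of a dimethylamino on this carbon therefore depends on what sits on the amide-type nitrogen, where methyl in place of hydrogen brings a 31-fold higher number from compound 2 to compound 4 (1.49 log units; beyond the scatter) and is the largest step so far.

No measurement shown explains this reversal. As far as these compounds go, whether an ethyl group on that nitrogen, or a pyrrolidine on the thiocarbonyl carbon, would track compound 2 or compound 4 stays open.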